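The source may report more compounds than this note shows. Statements on the series, on what has been measured and on what is new or still open speak of the compounds shown alone.

Two compounds of the series carry measured numbers: compound 1 `O=CN(C1CCCC1)C1CC1` and compound 2 `O=CN(C1CCC1)C1CCC1`. In an assay on isolated protein for inhibition of all-trans-retinol dehydrogenase [NAD(+)] ADH7 (Homo sapiens) (on this read-out higher numbers stand for weaker inhibition and lower numbers for stronger inhibition), compound 1 gives 930000 nM, and in this assay compound 2 gives 1800000 nM. Compound 1 holds the lowest of the two numbers, and the number for compound 2 lies within the usual scatter of it, so the two values show no difference that can be read as an order. Going by the values given here, no step between measured compounds that differ in a single place is available; compound 1 and compound 2 differ in two places, and only their two values can be stated.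

Compound 3 `O=CN(C1CCCC1)C1CCC1` is not yet measured in this assay. It differs from compound 1 by cyclobutyl in place of cyclopropyl on an amide-type nitrogen. Nothing in the two measured values separates the two ring sizes on this nitrogen; compound 2, which carries cyclobutyl there together with a second change, gives 1800000 nM. The step of a 1.3-fold higher number from compound 1 to compound 3 (0.11 log units; within the scatter) is therefore expected to stay within the scatter, leaning, if at all, toward a higher number. Compound 3 is estimated at 1200000 nM, with a range from 500000 nM to 3000000 nM.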

Compound 3, inhibition constant: 1100000 nM
The estimate for compound 3 lay 1.1-fold (0.04 log units) above the measured number, and the stated range covers the measured number.
By their numbers in this assay, from the lowest: compounds 1, 3 and 2 (each within the scatter of the next).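

Going by these compounds alone, compound 3 supplies the first comparison on this nitrogen that differs in one place only: in this assay, cyclobutyl in place of cyclopropyl gives a 1.2-fold higher number from compound 1 to compound 3 (0.07 log units; within the scatter). With the carbonyl carbon and the saturated ring carbon on the nitrogen kept as they are in compound 1, the two ring sizes therefore cannot be told apart on this read-out, something compound 1 and compound 2, which differ in two places, could not show. Nothing at hand bears on why these two ring sizes fall within the scatter of each other.

The compounds shown carry only small saturated carbon rings on the nitrogen, so this single step says nothing about whether a longer chain, a phenyl ring, or a ring or chain bearing an amine or a carboxylic acid would give a number beyond the scatter of compound 1. It also leaves open whether any replacement of the saturated ring on the other side of the nitrogen, or of the formyl hydrogen on the carbonyl carbon by a methyl group, would move the number in this assay at all.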